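Two amides and a pyrrolidine replacement on the carbonyl

This account rests on a few compounds, and the source may have more. Where it says the series, first, only, none or still open, it means among the compounds named here.

Among the measured compounds shown here, the series so far has two measured members. In an assay on isolated protein for inhibition of MAP kinase-activated protein kinase 2 (Homo sapiens), read by HTRF, tested at 10 uM (on this read-out lower numbers stand for less inhibition and higher numbers for more inhibition at the one concentration tested (going by the name of the read-out)), compound 1 `CN(CCCn1ccnc1)C(=O)[C@@H]1CCCN1c1nccc(Nc2ccccc2)n1` gives 2%, and compound 2 `Cc1cccc(Nc2ncnc3c2CN(C(=O)c2ccc(N(C)C)c4ccccc24)CC3)c1` gives 0% in this assay. The gap between them lies within the usual scatter, so compound 1 cannot be separated from compound 2 on these numbers; both sit near the floor of the read-out, and neither shows measurable inhibition at the single concentration tested. For the measured compounds named here, no pair of measured compounds differs in a single place, so no step in this assay is known.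

Compound 3 `COC[C@@H]1CCCN1C(=O)[C@@H]1CCCN1c1nccc(Nc2ccccc2)n1` has not been measured. It differs from compound 1 in one place: 2-(methoxymethyl)pyrrolidin-1-yl in place of (3-(1H-imidazol-1-yl)propyl)(methyl)amino on a carbonyl carbon. The change keeps the rest of compound 1 untouched. Going by the values given here, with compound 1 at 2% and no known step to learn from, no movement beyond the scatter is expected. The step of a number 1 percentage points higher from compound 1 to compound 3 (within the scatter) is expected to remain within the scatter. Compound 3 is estimated at 3% in this assay, with a range from -7% to 14%.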

Compound 3, a percentage reported as inhibition, at one concentration (the size of the read-out at that concentration, not a potency): 1%
Compound 3: the middle estimate sits 2 percentage points above what was measured, and the stated range covers the measured number.
By their numbers in this assay, from the lowest: compounds 2, 3 and 1 (each within the scatter of the next).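

Working notes on the carbonyl position. In this assay, among the compounds shown here, placing 2-(methoxymethyl)pyrrolidin-1-yl where (3-(1H-imidazol-1-yl)propyl)(methyl)amino stood on a carbonyl carbon gives a number 1 percentage points lower from compound 1 to compound 3 (within the scatter), the first step that can be read. The exchange swaps a five-membered aromatic ring with 2 hetero atoms for a five-membered non-aromatic ring with 1 hetero atom and adds 1 defined stereocentre, yet the read-out does not separate the two compounds, and both lie near the floor, so this position has so far shown no response that can be told from the scatter. No measurement is at hand that would explain this result.

On these data alone, it remains open whether a primary amine, a carboxylic acid or a longer alkyl chain on this carbonyl carbon would give a number clear of the scatter. Until a compound of this type shows clear inhibition in this assay, these numbers cannot show whether the group on the carbonyl carbon matters at all.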